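A few compounds are considered here, and "the series" means these few. Any claim that something is new, unique, unknown or untested is made for them only; others in the source may bear on it.

Of the compounds shown here, three built on one shared core have been tested in a functional assay, read by spectrophotometry, with a stated time of 30 min, tested at 5 ug/mL; a higher number here means a stronger effect of the compound at the concentration tested, a lower number a weaker effect. Compound 1 `CN1CCN(CC(=O)Nc2nc3ccccc3[nH]2)CC1` gives 11%. Compound 2 `O=C(CN1CCN(c2ccccc2F)CC1)Nc1nc2ccccc2[nH]1` gives 11.6%, and compound 3 `O=C(CN1CCN(c2ncccn2)CC1)Nc1nc2ccccc2[nH]1` gives 8.77%. On these numbers compound 3 stands lowest of the three, yet both others lie within the scatter of it: the step of a number 2.2 percentage points lower from compound 1 to compound 3 (within the scatter) and the step of a number 2.8 percentage points lower from compound 2 to compound 3 (within the scatter) are both small, and so is the step of a number 0.6 percentage points higher from compound 1 to compound 2 (within the scatter). Compound 4 `O=C(CN1CCN(c2ccc([N+](=O)[O-])cc2)CC1)Nc1nc2ccccc2[nH]1` has not yet been measured. It differs from compound 3 in one place: 4-nitrophenyl in place of pyrimidin-2-yl on an amine nitrogen in a ring. All three measured steps exchange the group on the same ring nitrogen, moving between methyl, 2-fluorophenyl and pyrimidin-2-yl, and none of them shifted this assay beyond the scatter. Within the data shown here, no measured compound carries 4-nitrophenyl. The expected step from compound 3 to compound 4 is a number 1.2 percentage points higher from compound 3 to compound 4 (within the scatter), not beyond the scatter. Compound 4 is estimated to give about 10%, with a range from 4% to 18%.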

Compound 4, a percentage reported as activity, at one concentration (the size of the read-out at that concentration, not a potency): 16.1%
Compound 4: middle estimate off by 6.1 percentage points, on the low side, within the range that was stated.
By their numbers in this assay, from the lowest: compounds 3, 1, 2 and 4 (each within the scatter of the next).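

On the amine nitrogen in the ring, 4-nitrophenyl is the only group shown that carries oxygen and a double bond outside aromatic rings, yet in this assay all its steps stay within the scatter: a number 7.3 percentage points higher from compound 3 to compound 4 (within the scatter), a number 4.5 percentage points higher from compound 2 to compound 4 (within the scatter) and a number 5.1 percentage points higher from compound 1 to compound 4 (within the scatter). Across methyl, 2-fluorophenyl, pyrimidin-2-yl and 4-nitrophenyl, no exchange at this position separates any two compounds beyond the scatter, so this change adds no measurable difference to the three earlier compounds. No measurement shown here offers an explanation for this result.

Still open, going by these compounds, is whether a different kind of group on this nitrogen, such as a carboxylic acid or a longer chain ending in an amine, would move the read-out beyond the scatter. The read-out also comes from a single concentration, so the relative potency of these compounds remains unknown.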